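Thiophene to heptynyl on the shared core

The compounds below may be only part of what the source reports. "The series", "measured", "known", "first", "only" and "open" are said of these compounds alone.

Three measured compounds frame the question. Compound 1 `O=c1[nH]c(=O)n(CCC(CO)CO)cc1-c1cccs1` in a functional assay on HeLa cells (Homo sapiens) for antiproliferative activity, read by MTT assay, with a stated time of 72 h (a higher number here means a weaker inhibitor, a lower number a stronger inhibitor), gives 7800 nM, the lowest of the three numbers. Compound 2 `CCCCCc1ccc(C#Cc2cn(CCC(COC(C)=O)COC(C)=O)c(=O)n(C(=O)c3ccccc3)c2=O)cc1` gives 79100 nM and compound 3 `CCCCCCCCC#Cc1cn(CCC(COC(C)=O)COC(C)=O)c(=O)n(C(=O)c2ccccc2)c1=O` gives 32400 nM, both well above compound 1. For the measured compounds named here, the only single-point step among the measured set is a 2.4-fold lower number from compound 2 to compound 3 (0.39 log units; beyond the scatter); it concerns the substituent on a triple-bonded carbon and not the exchange of an aromatic ring for an alkyne, so it bears only indirectly on the present question.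

Compound 4 `CCCCCC#Cc1cn(CCC(CO)CO)c(=O)[nH]c1=O` differs from compound 1 by hept-1-yn-1-yl in place of thiophen-2-yl on an aromatic carbon. Going by the values given here, no measured pair shows this exact exchange on an otherwise unchanged core. What can be said is that the two alkyne-bearing compounds 2 and 3 carry higher numbers than compound 1, though they also differ from compound 1 in other places, so their gap cannot be assigned to the alkyne alone. Given that, a modest rise in number for compound 4 relative to compound 1 is expected, with wide uncertainty, as a 1.5-fold higher number from compound 1 to compound 4 (0.19 log units; within the scatter). Compound 4 is accordingly estimated at 12000 nM in this assay , with a range from 4000 nM to 40000 nM.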

Compound 4, half-maximal inhibitory concentration: 76300 nM
The estimate for compound 4 lay 6.4-fold (0.80 log units) below the measured number; the measured number lies above the stated range.
By their numbers in this assay, from the lowest: compound 1; then compound 3; then compounds 4 and 2 (each within the scatter of the next).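

Read in this assay, this is the first direct measure of the exchange at this aromatic carbon, giving a 9.8-fold higher number from compound 1 to compound 4 (0.99 log units; beyond the scatter). The rest of the structure is unchanged, so the whole gap belongs to hept-1-yn-1-yl in place of thiophen-2-yl, whereas the earlier alkyne-bearing compounds also differed from compound 1 in other places and could not isolate it. The position is therefore not indifferent to this exchange, with the thiophen-2-yl compound carrying the lower number, but nothing available accounts for the gap.

The exchange alters several features at once, removing the five-membered aromatic ring and its sulfur while adding a triple bond and an open chain, so the compounds shown do not tell which of these changes carries the step. A saturated heptyl chain, a shorter alkyne such as prop-1-yn-1-yl, or a furan-2-yl or phenyl ring on the same carbon of the shared core would separate these features, and the series shown cannot yet say how any of them would read.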